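The compounds below may be only part of what the source reports. "The series", "measured", "known", "first", "only" and "open" are said of these compounds alone.

Of the compounds shown here, three from one series have been tested so far. Compound 1 `COc1ccc(Br)cc1Nc1cc(NC(=O)Nc2c(Cl)cccc2Cl)ncn1` gives 53% in a functional assay on HCC827 cells (Homo sapiens) for inhibition, read by MTT assay, with a stated time of 48 h, tested at 10 uM; on this read-out lower numbers stand for less inhibition and higher numbers for more inhibition at the one concentration tested (going by the name of the read-out). Compound 2 `COc1ccc(Nc2cc(NC(=O)Nc3c(Cl)cccc3Cl)ncn2)cc1C` gives 63.1% in this assay, and compound 3 `COc1cc(NC(=O)Nc2cc(Nc3cc(Br)ccc3OC)ncn2)cc(OC)c1` gives 76.3% in this assay, the highest of the three numbers, with its steps to compound 1 and to compound 2 both beyond the usual scatter.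

Two single changes connect these compounds. The change 4-methoxy-3-methylphenyl in place of 5-bromo-2-methoxyphenyl on a nitrogen on an aromatic ring brought a step of a number 10.1 percentage points higher from compound 1 to compound 2 (beyond the scatter). The change 3,5-dimethoxyphenyl in place of 2,6-dichlorophenyl on an amide-type nitrogen brought a larger step of a number 23.3 percentage points higher from compound 1 to compound 3 (beyond the scatter).

Compound 4 `COc1cc(NC(=O)Nc2cc(Nc3ccc(OC)c(C)c3)ncn2)cc(OC)c1` has not yet been measured. It differs from compound 3 by 4-methoxy-3-methylphenyl in place of 5-bromo-2-methoxyphenyl on a nitrogen on an aromatic ring, which is the same change that turned compound 1 into compound 2; the place is described in identical words in both cases, so it counts as the same change made on a different core. The two cores differ by 3,5-dimethoxyphenyl in place of 2,6-dichlorophenyl on an amide-type nitrogen. This change has been seen once, in the step from compound 1 to compound 2, and it went upward beyond the scatter, so an upward step of similar size is expected from compound 3 to compound 4, although a single precedent on another core gives only a rough guide, and the number on this read-out cannot rise without bound. Compound 4 is therefore estimated at 84% in this assay, with a likely range from 70% to 95%, which corresponds to an expected step of a number 7.7 percentage points higher from compound 3 to compound 4 (within the scatter).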

Compound 4, a percentage reported as inhibition, at one concentration (the size of the read-out at that concentration, not a potency): 48.3%
Compound 4: the middle estimate sits 35.7 percentage points above what was measured; the measured number lies below the stated range.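

The change to 4-methoxy-3-methylphenyl gave a number 28 percentage points lower from compound 3 to compound 4 (beyond the scatter) in this assay, so it pointed the opposite way on the second core and did not carry over: the same change on two cores in this assay, a number 10.1 percentage points higher (beyond the scatter) from compound 1 to compound 2 and a number 28 percentage points lower (beyond the scatter) from compound 3 to compound 4, 38.1 percentage points apart, beyond the scatter of two such steps
The other change, 3,5-dimethoxyphenyl in place of 2,6-dichlorophenyl on an amide-type nitrogen, gave a number 14.8 percentage points lower from compound 2 to compound 4 (beyond the scatter), and it also reversed direction between cores: the same change on two cores in this assay, a number 23.3 percentage points higher (beyond the scatter) from compound 1 to compound 3 and a number 14.8 percentage points lower (beyond the scatter) from compound 2 to compound 4, 38.1 percentage points apart, beyond the scatter of two such steps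
Together, these four compounds show that the two changes do not act independently here, since the result of each depends on the group at the other place, but they do not show why this happens or how widely it holds in the series.

The compounds shown pair only these two groups at each place, so it remains open whether the same reversal would appear with a plain phenyl, a morpholine or a carboxylic acid in their stead. Also open, as far as these compounds go, is whether the order seen at one concentration would hold in a full potency measurement, as each number here gives the size of the read-out at that single concentration.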